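The compounds below may be only part of what the source reports. "The series", "measured", "known", "first", "only" and "open" are said of these compounds alone.

Measured in an ADME assay on cells (Hepatocyte, Mus musculus) for cytotoxicity, read by MTT assay, with a stated time of 24 h; on this read-out higher numbers stand for lower toxicity in this test and lower numbers for higher toxicity in this test:
- compound 1 `Cc1ccc(C)c(S(=O)(=O)n2c(-c3cn(-c4ccccc4)nc3-c3ccc(F)cc3)nc3ccccc32)c1`: 122000 nM
- compound 2 `O=S(=O)(c1ccc(Br)cc1)n1c(-c2cn(-c3ccccc3)nc2-c2ccc(F)cc2)nc2ccccc21`: > 300000 nM, a limit of the assay and not a number

Compound 2 stands at the limit of > 300000 nM in this assay, at which 1 of the 2 values shown sits. Only a limit is therefore known for it, not an exact position.

Compound 3 `O=S(=O)(c1ccc(C(F)(F)F)cc1)n1c(-c2cn(-c3ccccc3)nc2-c2ccc(F)cc2)nc2ccccc21` differs from compound 2 in one group: trifluoromethyl in place of bromo on an aromatic carbon. In words, this is trifluoromethyl in place of bromo on an aromatic carbon, para to a large group.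

Among the measured compounds shown here, only one measured step bears on this change: an at least 2.4-fold higher number from compound 1 to compound 2 (0.39 log units; beyond the scatter). On these data alone, that step exchanged the whole group on the sulfonyl sulfur and was at least modest, and its true size remains open. The present change is narrower, since only the bromo leaves and the six-membered ring stays. For the measured compounds named here, no measurement yet shows what replacing bromo does in this assay, so no step beyond the scatter is expected in either direction.

The step expected is a number no higher from compound 2 to compound 3 (the limit leaves the size open). For compound 3 the estimated value is 300000 nM, with an expected range of 130000 nM to 600000 nM. The assay may well report only a limit for this compound too.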

Compound 3, half-maximal cytotoxic concentration: 55300 nM
Estimate against measurement, compound 3: 5.4-fold (0.73 log units) above; measured number below the stated range.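

In this assay, the group at this one position clearly matters: with the six-membered aromatic ring kept, trifluoromethyl in place of bromo gives an at least 5.4-fold lower number from compound 2 to compound 3 (0.73 log units; beyond the scatter). The earlier pair had exchanged the whole group on the sulfonyl sulfur, whereas this change shows that a single substituent on that ring can shift the read-out toward higher toxicity in this test, and the comparison with the 2,5-dimethylphenyl group gives a 2.2-fold lower number from compound 1 to compound 3 (0.34 log units; beyond the scatter), so replacing 2,5-dimethylphenyl can raise or lower the number depending on which 4-substituted phenyl group enters. Compound 2 is known only by a limit of the assay, so the full size of its step to compound 3 stays open: the limit of > 300000 nM in this assay, at which 1 of the 3 values shown sits.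

On these data alone, with only bromo and trifluoromethyl compared at this position, it remains open whether other groups there, such as chloro, methoxy or an amine, would give numbers closer to compound 2 or to compound 3. As far as these compounds go, it also remains open whether the same exchange would have a similar effect on a different group on the sulfonyl sulfur or with a different core.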